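The source may hold more compounds than are shown below. What is called first, only, known or untested is meant among the compounds shown, and "the series" means these compounds.

Measured in a functional assay on HeLa cells (Homo sapiens) for antiproliferative activity, read by MTT assay, with a stated time of 48 h; a higher number here means a weaker inhibitor, a lower number a stronger inhibitor:
- Compound 1 `O=[N+]([O-])c1cccc(-c2nn(-c3ccccc3)cc2C(Nc2nc3ccccc3s2)c2c(O)ccc3ccccc23)c1`: 8220 nM
- Compound 2 `COc1cccc(-c2nn(-c3ccccc3)cc2C(Nc2nc3ccccc3s2)c2c(O)ccc3ccccc23)c1`: 14900 nM
- Compound 3 `Cc1ccc(-c2nn(-c3ccccc3)cc2C(Nc2nc3ccccc3s2)c2c(O)ccc3ccccc23)cc1`: 8050 nM

Compound 2 does not stand apart from the other two, since its measured steps are a 1.8-fold higher number from compound 1 to compound 2 (0.26 log units; within the scatter) and a 1.9-fold lower number from compound 2 to compound 3 (0.27 log units; within the scatter). The remaining step is a 1.0-fold lower number from compound 1 to compound 3 (0.01 log units; within the scatter).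

Compound 4 `COc1cccc(-c2nn(-c3ccccc3)cc2C(Nc2nc3ccc(OC)cc3s2)c2c(O)ccc3ccccc23)c1` differs from compound 2 by methoxy in place of hydrogen on an aromatic carbon, giving 6-methoxy-1,3-benzothiazol-2-yl. For the measured compounds named here, no measured step makes this change. The three measured steps only exchange groups on the 3-nitrophenyl, 3-methoxyphenyl and 4-methylphenyl position, so they are indirect guides. Their small size gives no reason to expect a clear shift in this assay, and no direction can be favoured. The expected change is a 1.2-fold lower number from compound 2 to compound 4 (0.09 log units; within the scatter), which means no step beyond the scatter. For compound 4 the estimated value is 12000 nM, with an expected range of 5000 nM to 28000 nM.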

Compound 4, half-maximal inhibitory concentration: 10500 nM
Estimate against measurement, compound 4: 1.1-fold (0.06 log units) above, and the stated range covers the measured number.
By their numbers in this assay, from the lowest: compounds 3, 1, 4 and 2 (each within the scatter of the next).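

This is the first change shown on the 1,3-benzothiazol-2-yl group, as the earlier steps only exchanged the other aromatic group. In this assay, adding methoxy to give 6-methoxy-1,3-benzothiazol-2-yl produces a 1.4-fold lower number from compound 2 to compound 4 (0.15 log units; within the scatter) and so has no effect that can be told from the scatter. Nothing shown gives a reason for this result. From the compounds shown here alone, whether an amine, a carboxylic acid or a longer chain at this carbon would fare the same remains open. So does whether methoxy here behaves alike with the 3-nitrophenyl or 4-methylphenyl group present.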